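This account rests on a few compounds, and the source may have more. Where it says the series, first, only, none or still open, it means among the compounds named here.

In a functional assay for antagonist activity at thyroid hormone receptor alpha (Homo sapiens), read by fluorescence polarization (on this read-out lower numbers stand for stronger inhibition and higher numbers for weaker inhibition), compound 1 `CC1Cc2ccccc2N1C(=O)c1sc(-c2ccc(S(C)(=O)=O)c([N+](=O)[O-])c2)nc1C(F)(F)F` gives 1100 nM. Exchanging the 2-methyl-2,3-dihydro-1H-indol-1-yl on the carbonyl carbon for 4-methylpiperidin-1-yl leads to compound 2 `CC1CCN(C(=O)c2sc(-c3ccc(S(C)(=O)=O)c([N+](=O)[O-])c3)nc2C(F)(F)F)CC1`, which in this assay gives 190 nM; this amounts to a 5.8-fold lower number from compound 1 to compound 2 (0.76 log units; beyond the scatter). Compound 2 thus holds the lower of the two numbers recorded, compound 1 being its only comparator. Compound 3 `CS(=O)(=O)c1ccc(-c2nc(C(F)(F)F)c(C(=O)N3CCCCC3)s2)cc1[N+](=O)[O-]` differs from compound 2 by hydrogen in place of methyl on a saturated ring carbon, which trims 4-methylpiperidin-1-yl to piperidin-1-yl. Among the measured compounds shown here, no measured step in this set touches that change: the single step known, from compound 1 to compound 2, swaps the whole ring on the carbonyl carbon and says nothing about a methyl on a saturated ring carbon. For compound 3 the step is therefore expected to be a 1.4-fold higher number from compound 2 to compound 3 (0.14 log units; within the scatter), within the scatter. Compound 3 is accordingly estimated at 260 nM, in the range 100 nM to 700 nM.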

Compound 3, half-maximal inhibitory concentration: 100 nM
Compound 3: the middle estimate sits 2.6-fold (0.41 log units) above what was measured, within the range that was stated.
By their numbers in this assay, from the lowest: compounds 3 and 2 (each within the scatter of the next); then compound 1.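

Hydrogen in place of methyl on a saturated ring carbon, three ring bonds from the ring nitrogen, gives a 1.9-fold lower number from compound 2 to compound 3 (0.28 log units; within the scatter) and so shows that the methyl of 4-methylpiperidin-1-yl is not needed to keep the number seen with compound 2. Piperidin-1-yl in place of 2-methyl-2,3-dihydro-1H-indol-1-yl on the carbonyl carbon gives an 11-fold lower number from compound 1 to compound 3 (1.04 log units; beyond the scatter) and so shows that the advantage over that group, first seen with 4-methylpiperidin-1-yl, does not depend on the methyl. Nothing on hand offers a reason for either step.

The compounds shown leave open what a hydroxyl, an amine, a carboxylic acid or a longer chain such as ethyl would do on that same ring carbon. They also leave open how pyrrolidin-1-yl or morpholin-4-yl would compare on the carbonyl carbon.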